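Allyloxy in place of ethoxy on the three-carbon linker

A few compounds are considered here, and "the series" means these few. Any claim that something is new, unique, unknown or untested is made for them only; others in the source may bear on it.

Compound 3 `CCOc1ccc2c(NCCCN(C)C)ccnc2c1` gives 6780 nM in a functional assay on SK-OV-3 cells (Homo sapiens) for cytotoxicity, read by MTT assay, with a stated time of 48 h (a lower number here means a stronger inhibitor, a higher number a weaker inhibitor), and stands highest of the three measured compounds; compound 1 `C=CCOc1ccc2c(NCCN(C)C)ccnc2c1` gives 1560 nM and compound 2 `CN(C)CCCNc1ccnc2cc(OCc3ccc(F)cc3)ccc12` gives 1280 nM. The change to compound 4 `C=CCOc1ccc2c(NCCCN(C)C)ccnc2c1` is vinyl in place of methyl on a saturated chain carbon bound to an oxygen on an aromatic ring. For the measured compounds named here, the only measured step at that carbon is a 5.3-fold higher number from compound 2 to compound 3 (0.72 log units; beyond the scatter), which shows that a larger group on that position lowered the number; compound 1, which also carries allyloxy but a shorter linker, sits well below compound 3. The change to vinyl is far smaller than to 4-fluorophenyl, so a modest downward step a 2.6-fold lower number from compound 3 to compound 4 (0.42 log units; beyond the scatter) is expected. Compound 4 is estimated at 2600 nM, within 1200 nM to 5600 nM.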

Compound 4, half-maximal inhibitory concentration: 4250 nM
The estimate for compound 4 lay 1.6-fold (0.21 log units) below the measured number, and the stated range covers the measured number.
By their numbers in this assay, from the lowest: compounds 2 and 1 (each within the scatter of the next); then compounds 4 and 3 (each within the scatter of the next).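

In this assay, ethoxy to allyloxy on the longer linker gives a 1.6-fold lower number from compound 3 to compound 4 (0.20 log units; within the scatter) and the two cannot be told apart, whereas 4-fluorophenyl on that carbon still separates from vinyl (a 3.3-fold higher number from compound 2 to compound 4 (0.52 log units; beyond the scatter)). With allyloxy held fixed, the linker can now be read alone: (dimethylamino)methyl in place of dimethylamino gives a 2.7-fold higher number from compound 1 to compound 4 (0.44 log units; beyond the scatter) and so favours the shorter chain. Nothing measured here accounts for these steps.

Open, from the compounds shown here alone, is whether the 4-fluorophenyl result depends on the fluorine, which an unsubstituted phenyl would test. Also open, going by these compounds, is whether a longer chain or a morpholine in place of dimethylamino continues the linker trend.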